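A few compounds are considered here, and "the series" means these few. Any claim that something is new, unique, unknown or untested is made for them only; others in the source may bear on it.

Measured in a functional assay on OVCAR-3 cells (Homo sapiens) for cytotoxicity, read by MTT assay, with a stated time of 6 days (on this read-out lower numbers stand for stronger inhibition and higher numbers for weaker inhibition), are:
Compound 1 `COc1ccc(NC(=O)SC[C@H](NC(C)=O)C(=O)O)cc1` gives > 200000 nM as a limit
Compound 2 `CC(=O)N[C@@H](CSC(=O)Nc1ccccc1)C(=O)O` gives 153000 nM as a number
Compound 3 `CC(=O)N[C@@H](CSC(=O)Nc1ccc(F)cc1)C(=O)O` gives > 200000 nM as a limit

Compound 3 thus has only its limit of > 200000 nM and no number. Compound 4 `CC(=O)N[C@@H](CSC(=O)Nc1ccc(Cl)cc1)C(=O)O` differs from it by chloro in place of fluoro on an aromatic carbon in one change, chloro in place of fluoro on an aromatic carbon, para to a large group.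

Within the data shown here, two measured steps bear on this place, an at least 1.3-fold lower number from compound 1 to compound 2 (0.11 log units; that floor lies within the scatter) and an at least 1.3-fold higher number from compound 2 to compound 3 (0.11 log units; that floor lies within the scatter), and both floors lie within the scatter. The third, a step that the two limits leave unreadable from compound 1 to compound 3, cannot be sized.

With steps this small, the expected change is an at least 1.4-fold lower number from compound 3 to compound 4 (0.15 log units; that floor lies within the scatter) in this assay, toward lower numbers but not expected to exceed the scatter. Compound 4 is estimated at 140000 nM, with an expected range from 60000 nM to 200000 nM.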

Compound 4, half-maximal inhibitory concentration in the OVCAR-3 assay: > 200000 nM
Compound 4: only a limit was reported; the forecaster's own chance of this, stated with the estimate: 45%; at least 1.4-fold (0.15 log units) between middle value and limit.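

In the OVCAR-3 assay, compound 2 gives 153000 nM. In the OVCAR-3 assay, compound 4 gives > 200000 nM, which is a limit. In the OVCAR-3 assay, chloro in place of hydrogen at this place, para to a large group, gives an at least 1.3-fold higher number from compound 2 to compound 4 (0.11 log units; that floor lies within the scatter). The steps between two limits cannot be read, so chloro in place of fluoro has a readable size only in a physicochemical assay for solubility (on this read-out lower numbers stand for lower solubility and higher numbers for higher solubility), with a 1.9-fold higher number from compound 3 to compound 4 (0.27 log units; within the scatter). In the physicochemical assay, compound 3 gives 388 ug/mL and compound 4 gives 721 ug/mL. Compound 4 ends at a limit as well, so this change adds a further compound at the same limit: the limit of > 200000 nM in the OVCAR-3 assay, at which 3 of the 4 values shown sit. The compounds shown leave open whether an amine or a nitrile at this place would give a readable number in the OVCAR-3 assay.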